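A few compounds are considered here, and "the series" means these few. Any claim that something is new, unique, unknown or untested is made for them only; others in the source may bear on it.

Measured so far:
compound 1, `O=C1C(=O)N(Cc2ccc(-c3ccncc3)cn2)c2ccc(OC(F)(F)F)cc21`: "not determined" (no result reported)
compound 2, `O=C1C(=O)N(Cc2ccc(Cl)nc2)c2ccc(OC(F)(F)F)cc21`: 80%
compound 3, `O=C1C(=O)N(Cc2ccc(-c3ccccc3)cn2)c2ccc(OC(F)(F)F)cc21`: 47%

The three compounds share one core, an isatin-like bicycle carrying a trifluoromethoxy group, joined through a methylene to a pyridine that differs from one compound to the next. Compound 1 carries a pyridyl group on that ring, but in a functional assay on CHO cells for positive allosteric modulation of muscarinic acetylcholine receptor M5 (Homo sapiens), read by FLIPR and calcium flux, with a stated time of 1 h (a lower number here means a smaller maximal response, a higher number a larger maximal response), compound 1 has no reported number. Of the two numbers that exist, compound 2 stands highest; the nearest is compound 3, whose maximal response lies a good way lower, a gap beyond the usual scatter.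

The step to the unmeasured compound 4, `O=C1C(=O)N(Cc2ccc(-c3ccccc3)nc2)c2ccc(OC(F)(F)F)cc21`, replaces the chloro of compound 2 with a phenyl: phenyl in place of chloro on an aromatic carbon. Going by the values given here, no step between two measured compounds isolates this exact change, so the expectation rests on the fact that the one phenyl-bearing compound measured, compound 3, gives 47%, below compound 2. A downward step of moderate size seems the more likely outcome in this assay, although the phenyl in compound 3 sits at a different place and the comparison is loose.

Compound 4 is therefore expected to reach about 60%, plausibly between 40% and 82%, which would mean an estimated step of a number 20 percentage points lower from compound 2 to compound 4 (beyond the scatter).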

Compound 4, largest response reached (Emax), in percent of the reference or control that the assay uses: 76%
Beside the measured number, compound 4's estimate is 16 percentage points below it, and the stated range covers the measured number.
By their numbers in this assay, from the lowest: compound 3; then compounds 4 and 2 (each within the scatter of the next).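

In this assay the swap of chloro for phenyl, on an aromatic carbon next to the ring nitrogen, is a step of a number 4 percentage points lower from compound 2 to compound 4 (within the scatter) and so leaves the two compounds indistinguishable in maximal response. Going by these compounds alone, this is the first pair that differs in one place only, and it shows that this position accepts a whole six-membered aromatic ring of carbon, with 6 heavy atoms entering where 1 leaves, without a loss that stands out from the scatter. No measurement shown here explains why the larger group is accepted.

Within the data shown here, what remains open is how far this acceptance reaches, since chloro and phenyl are the only two groups compared at this carbon, and an amine such as morpholine, a carboxylic acid or a longer alkyl chain could give quite a different maximal response. Among these compounds, the single step also cannot say whether phenyl would be accepted as well on a different core, or whether a substituted phenyl, for example one carrying a methoxy group, would behave like the plain ring.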